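Swapping One Saturated Ring for Another in a Soluble Series

A few compounds are considered here, and "the series" means these few. Any claim that something is new, unique, unknown or untested is made for them only; others in the source may bear on it.

The compounds share one core and differ in the group carried on a saturated chain carbon. Compound 1, `COc1ccc2[nH]c(C(=O)N3CC(=O)N(Cc4ccccc4)[C@@H](CN4CCC(OC)CC4)C3)cc2c1`, was tested in a physicochemical assay for solubility, read by spectrophotometry, in phosphate buffer, with a stated time of 2 h, at pH 7.4 (a lower number here means a less soluble compound, a higher number a more soluble compound), where compound 1 gives > 25000 nM, which is a limit of the assay rather than a number. Compound 1 thus stands at the limit of > 25000 nM in this assay, at which 1 of the 3 values shown sits. Compound 2, `COc1ccc2[nH]c(C(=O)N3CC(=O)N(Cc4ccccc4)[C@@H](CN4CCN(S(=O)(=O)c5ccccc5)CC4)C3)cc2c1`, gives 16900 nM in this assay. Compound 3, `COc1cccc(CN2C(=O)CN(C(=O)c3cc4cc(OC)ccc4[nH]3)C[C@@H]2c2ccccc2)c1`, gives 13600 nM in this assay, and these two values lie within the usual scatter of each other.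

Compound 4, `COc1ccc2[nH]c(C(=O)N3CC(=O)N(Cc4ccccc4)[C@@H](CN4[C@H](C)COC[C@@H]4C)C3)cc2c1`, has not yet been measured in this assay. It differs from compound 1 in one place: 3,5-dimethylmorpholin-4-yl in place of 4-methoxypiperidin-1-yl on a saturated chain carbon bound to a saturated ring carbon. Among the measured compounds shown here, no step between measured compounds matches this change, and the two structures have the same atoms, joined differently. For this reason compound 4 is expected to show no shift beyond the scatter, and the estimated step of an at least 1.1-fold lower number from compound 1 to compound 4 (0.05 log units; that floor lies within the scatter) reflects that expectation. Compound 4 is therefore estimated at 22000 nM, with a likely range from 9000 nM to 50000 nM.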

Compound 4, solubility: > 100000 nM
Compound 4: no number, only a limit (the forecaster's own chance of this, stated with the estimate: 45%); middle value at least 4.5-fold (0.65 log units) away from the limit.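

Among the compounds shown here, compound 1 and compound 4 both give only limits in this assay, not numbers, so no step between them can be read. Going by these compounds, how far 3,5-dimethylmorpholin-4-yl in place of 4-methoxypiperidin-1-yl shifts the solubility read-out, and in which direction, stays open.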